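The source may report more compounds than this note shows. Statements on the series, on what has been measured and on what is new or still open speak of the compounds shown alone.

In an ADME assay on microsomes from liver (Mus musculus) for metabolic stability, read by LC-MS, using NADPH, with a stated time of 60 min (on this read-out higher numbers stand for a more stable compound and lower numbers for a less stable compound), compound 1 `Fc1ccccc1Oc1ncnc2scc(C(F)(F)F)c12` gives < 5%, which is a limit of the assay and not a number. Compound 2 `CC(C)(C)c1sc2ncnc(Oc3ccccc3F)c2c1-c1ccc(F)cc1` gives < 5%, again a limit. Among the measured compounds shown here, compound 3 `CC(C)(C)c1sc2ncnc(Oc3ccccc3OC(F)(F)F)c2c1-c1ccc(F)cc1` reads 5%, the only actual number among the measured compounds.

Compound 4 `CC(C)(C)c1sc2ncnc(Oc3ccccc3OC(F)(F)F)c2c1-c1ccc(Cl)c(Cl)c1` differs from compound 3 in one place: 3,4-dichlorophenyl in place of 4-fluorophenyl on an aromatic carbon. It carries 3,4-dichlorophenyl in place of 4-fluorophenyl on an aromatic carbon, next to the ring atom that bears a tert-butyl group.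

For the measured compounds named here, no measured step makes this same exchange. The nearest evidence is a number no lower from compound 2 to compound 3 (the limit leaves the size open), where trifluoromethoxy takes the place of fluoro on an aromatic carbon. That step changes a different place in the molecule, and its size cannot be read, so it gives no measure for the new exchange. The expectation therefore rests mainly on compound 3 at 5% and on the crowding of the values at the limit of < 5% in this assay, at which 2 of the 3 values shown sit.

In this assay, the expected a number 1 percentage points lower from compound 3 to compound 4 (within the scatter) stays within the usual scatter, with no direction favoured. Compound 4 is estimated at 4%, with an expected range from 1% to 10%.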

Compound 4, percent of the compound remaining: 25%
The estimate for compound 4 lay 21 percentage points below the measured number; measured number outside the range, above it.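

In this assay, 3,4-dichlorophenyl in place of 4-fluorophenyl gives a number 20 percentage points higher from compound 3 to compound 4 (beyond the scatter), which shows that the read-out responds to a change at this place on the shared core, two ring bonds from the ring sulfur. The earlier step between compound 2 and compound 3 cannot be read, so this is the first step among the compounds shown whose size is known. Compound 4 also stands clear of the values crowded at the low end of this read-out: the limit of < 5% in this assay, at which 2 of the 4 values shown sit.

Going by these compounds, what stays open is whether a single chlorine on this phenyl ring would give a step of the same size, and how a methoxy group, a nitrile or an amine on that ring would read. The compounds shown also leave open whether 3,4-dichlorophenyl would give a similar step with fluoro in place of trifluoromethoxy on the other aromatic ring, the arrangement that compound 2 carries with 4-fluorophenyl.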